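The source may report more compounds than this note shows. Statements on the series, on what has been measured and on what is new or still open speak of the compounds shown alone.

Measured so far in a functional assay (aorta) with Rattus norvegicus as the target; a higher number here means that more compound is needed for the effect, a lower number that less compound is needed:
- compound 1 `CC(C)(C)C[C@H](N)C(=O)Nc1cc2cc[nH]c(=O)c2cc1Cl` gives ("not determined" (no result reported))
- compound 2 `N[C@H](C(=O)Nc1cc2cc[nH]c(=O)c2cc1Cl)C1CCCCC1` gives (180 nM)

Compound 1 has no single number in this assay and so offers no starting value of its own. Among the measured compounds shown here, the only number belongs to compound 2 (180 nM).

Compound 3 `CN1CCC(C(=O)Nc2cc3cc[nH]c(=O)c3cc2Cl)CC1` has not yet been measured. Its change from compound 1 is 1-methylpiperidin-4-yl in place of 1-amino-3,3-dimethylbutyl on a carbonyl carbon. For the measured compounds named here, the series holds no measured step between compounds, so the size of this change cannot be read from the data and any figure remains a judgement. A step beyond the scatter is nevertheless expected, towards a higher number in this assay and thus more compound needed, taking compound 2 (180 nM) as the sole anchor. The uncertainty is wide, and a result close to that anchor would not be surprising. For compound 3 the expected value is 800 nM (estimated range 150 nM to 4000 nM).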

Compound 3, half-maximal effective concentration: 250 nM
Estimate against measurement, compound 3: 3.2-fold (0.51 log units) above; the range from low to high includes it.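

In this assay, among the compounds shown here, compound 1 gives "not determined" (no result reported), so no step from it to compound 3 can be read. The compounds shown leave open how replacing 1-amino-3,3-dimethylbutyl with 1-methylpiperidin-4-yl on the carbonyl carbon shifts the effective concentration. No data shown here offer an explanation for the value of compound 3.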